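Swapping a Nitrile for a Hydroxyl on the Phenyl Ring

The source may hold more compounds than are shown below. What is called first, only, known or untested is meant among the compounds shown, and "the series" means these compounds.

Compound 1 `CC1(C)[C@H]2CC[C@]1(C)N(Cc1cn(-c3ccccc3C#N)nn1)C(=O)C2`: 180 nM
Compound 2 `COc1ccccc1-n1cc(CN2C(=O)C[C@@H]3CC[C@@]2(C)C3(C)C)nn1`: 110 nM

Both were tested in a functional assay on HepG2 cells (Homo sapiens) for inhibition, read by MTT assay, with a stated time of 24 h; a lower number here means a stronger inhibitor, a higher number a weaker inhibitor. Compound 1 has the highest of the two numbers, with compound 2 nearest; the step of a 1.6-fold lower number from compound 1 to compound 2 (0.21 log units; within the scatter) is too small to count as a real difference. Compound 3 `CC1(C)[C@H]2CC[C@]1(C)N(Cc1cn(-c3ccccc3O)nn1)C(=O)C2` is compound 1 with hydroxy in place of cyano on an aromatic carbon. Among the compounds with values here, only the step from compound 1 to compound 2 bears on this, as it replaces the same cyano, and it stayed within the scatter; no measured compound carries a hydroxy group. The expected change is therefore a 1.2-fold lower number from compound 1 to compound 3 (0.08 log units; within the scatter), nothing beyond the scatter. Compound 3 is estimated at 150 nM, within a range from 60 nM to 400 nM.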

Compound 3, half-maximal inhibitory concentration: 120 nM
Beside the measured number, compound 3's estimate is 1.3-fold (0.10 log units) above it; the measured number falls inside the stated range.
By their numbers in this assay, from the lowest: compounds 2, 3 and 1 (each within the scatter of the next).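

In this assay, hydroxy carries a hydrogen-bond donor and cyano does not, yet this change gives a 1.5-fold lower number from compound 1 to compound 3 (0.18 log units; within the scatter) on the aromatic carbon. Hydrogen in place of methyl on the oxygen gives a 1.1-fold higher number from compound 2 to compound 3 (0.04 log units; within the scatter) and so also stays within the scatter, leaving cyano, methoxy and hydroxy indistinguishable at this position in these three compounds. No measurement that could explain this result is available. On these data alone, whether an amine or a carboxylic acid at this position would also stay within the scatter remains open.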